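Ring enlargement on the amino substituent of compound 2

This account rests on a few compounds, and the source may have more. Where it says the series, first, only, none or still open, it means among the compounds named here.

Compound 1 `Cn1c(-c2ccccc2)nc2c(NC3CCCCC3)ncnc21` and compound 2 `CCCn1c(-c2ccccc2)nc2c(NC3CCCC3)ncnc21` share a core and differ in two places. In a functional assay on CHO cells for antagonist activity at adenosine receptor A2b (Homo sapiens), read by 33P incorporation, with a stated time of 20 min (a higher number here means a weaker inhibitor, a lower number a stronger inhibitor), compound 1 gives only a limit of the assay, > 30000 nM. In this assay compound 2 gives 3430 nM, the only number reported so far among these compounds. Compound 3 `CCCn1c(-c2ccccc2)nc2c(NC3CCCCC3)ncnc21` differs from compound 2 in one place: cyclohexyl in place of cyclopentyl on a nitrogen on an aromatic ring. For the measured compounds named here, no step between measured compounds covers this change. The expected step is a 2.3-fold higher number from compound 2 to compound 3 (0.37 log units; beyond the scatter), toward weaker inhibition and probably beyond the usual scatter. The estimate for compound 3 in this assay is 8000 nM, within 2500 nM to 30000 nM.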

Compound 3, inhibition constant: 5310 nM
Beside the measured number, compound 3's estimate is 1.5-fold (0.18 log units) above it; the measured number falls inside the stated range.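

In this assay the ring enlargement gives a 1.5-fold higher number from compound 2 to compound 3 (0.19 log units; within the scatter) with cyclohexyl in place of cyclopentyl on a nitrogen on an aromatic ring, so compound 2 and compound 3 stand within the scatter of each other. The chain on the aromatic nitrogen gives an at least 5.6-fold lower number from compound 1 to compound 3 (0.75 log units; beyond the scatter) with ethyl in place of hydrogen on a saturated chain carbon. Compound 1 gives only a limit, so that step has a bound and no exact size: the limit of > 30000 nM in this assay, at which 1 of the 3 values shown sits.

From the compounds shown here alone, whether a longer chain there, or an amine on the cyclohexyl ring, would move the number stays open.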